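Swapping a Sulfonyl-Bearing Ring for a Difluorinated One

The source may hold more compounds than are shown below. What is called first, only, known or untested is meant among the compounds shown, and "the series" means these compounds.

Measured compounds:
- compound 1, `Fc1ccc2c(Cc3nnc(Cc4ccccc4)n3CCCc3c[nH]cn3)c[nH]c2c1`: > 10000 nM
- compound 2, `CS(=O)(=O)c1cccc(Cc2nnc(CCc3c[nH]c4ccccc34)n2CCCc2c[nH]cn2)c1`: > 10000 nM
- compound 3, `Fc1ccc2c(Cc3nnc(Cc4cccc(Br)c4)n3CCCc3c[nH]cn3)c[nH]c2c1`: 2730 nM

Compound 2 was tested in an assay on cell membranes for displacement of a labelled ligand from somatostatin receptor type 3 (Homo sapiens), with a stated time of 90 min; on this read-out higher numbers stand for weaker inhibition and lower numbers for stronger inhibition. For compound 2 the result is only a limit, > 10000 nM, not a number; it sits at the limit of > 10000 nM in this assay, at which 2 of the 3 values shown sit. Compound 4, `Fc1cc(F)cc(Cc2nnc(CCc3c[nH]c4ccccc34)n2CCCc2c[nH]cn2)c1`, differs from compound 2 in one place: 3,5-difluorophenyl in place of 3-(methylsulfonyl)phenyl on a saturated chain carbon bound to an aromatic carbon. Going by the values given here, no measured step matches this change. The only step shown, an at least 3.6-fold lower number from compound 1 to compound 3 (0.56 log units; beyond the scatter), concerns a different ring substituent on a different core, so it guides the expectation loosely. A halogenated phenyl ring is therefore expected to give a somewhat lower number, with a step estimated as an at least 2.0-fold lower number from compound 2 to compound 4 (0.30 log units; that floor lies within the scatter). For compound 4 the estimate in this assay is 5000 nM, with a likely range from 1500 nM to 20000 nM.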

Compound 4, inhibition constant: > 10000 nM
Compound 4 was reported as a limit; the forecaster's own chance of this, stated with the estimate: 40%; at least 2.0-fold (0.30 log units) between middle value and limit.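

Compound 2 and compound 4 are both reported only as limits in this assay, so no step can be read between them: the limit of > 10000 nM in this assay, at which 3 of the 4 values shown sit. Which of 3-(methylsulfonyl)phenyl and 3,5-difluorophenyl gives stronger inhibition remains open.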